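A few compounds are considered here, and "the series" means these few. Any claim that something is new, unique, unknown or untested is made for them only; others in the source may bear on it.

Of the compounds shown here, two have been tested in an ADME assay for inhibition of prostaglandin G/H synthase 1 (Rattus norvegicus), with a stated time of 30 min; a lower number here means a stronger inhibitor, a higher number a weaker inhibitor. Compound 1 `CN1C=CN(C2NC(C(Cl)(Cl)Cl)=CN2c2ccc(S(N)(=O)=O)cc2)C=C1` gives 86000 nM in this assay, and compound 2 `CN1C=CC(C2OC(C(F)(F)F)=CN2c2ccc(S(N)(=O)=O)cc2)C=C1` gives 50200 nM. These two numbers lie within the usual scatter of each other, and neither can be told apart from the other; both compounds are weak inhibitors here. Compound 3 `CC1=CN(c2ccc(S(N)(=O)=O)cc2)C(N2C=CN(C)C=C2)N1` has not yet been measured. It differs from compound 1 in one place: methyl in place of trichloromethyl on a double-bonded ring carbon. Among the compounds with values here, no measured pair shows what this change does to the numbers in this assay, and the weak values of compound 1 and compound 2 are the only footing. Compound 3 is expected to remain a weak inhibitor, with the step of a 1.2-fold higher number from compound 1 to compound 3 (0.07 log units; within the scatter) expected to stay within the scatter. In this assay compound 3 is estimated at 100000 nM, with a likely range from 30000 nM to 300000 nM.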

Compound 3, half-maximal inhibitory concentration in the prostaglandin G/H synthase 1 assay: 90700 nM
Compound 3: middle estimate off by 1.1-fold (0.04 log units), on the high side; the range from low to high includes it.
By their numbers in the prostaglandin G/H synthase 1 assay, from the lowest: compounds 2, 1 and 3 (each within the scatter of the next).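

In the prostaglandin G/H synthase 1 assay, putting methyl in place of trichloromethyl on this double-bonded ring carbon gives a 1.1-fold higher number from compound 1 to compound 3 (0.02 log units; within the scatter), so this first measured pair at the position shows that replacing the larger group with the smaller one leaves the two inhibition numbers indistinguishable. In a physicochemical assay for acid dissociation, compound 1 gives 7.68 and compound 3 gives 7.11. In the physicochemical assay this is a number 0.57 log units lower from compound 1 to compound 3 (beyond the scatter), so the same change does register in acid dissociation, even though it does not separate the two compounds as inhibitors.

From the compounds shown here alone, compound 1 and compound 3 carry only trichloromethyl and methyl at this position, so it remains open whether an amine, a carboxylic acid or a longer chain there would give a different number in the prostaglandin G/H synthase 1 assay. Going by these compounds, it is also open whether a similar shift in acid dissociation would matter in a stronger inhibitor.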